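This account rests on a few compounds, and the source may have more. Where it says the series, first, only, none or still open, it means among the compounds named here.

In a functional assay on MDA-MB-231 cells (Homo sapiens) for cytotoxicity, read by MTT assay, with a stated time of 48 h (a higher number here means a weaker inhibitor, a lower number a stronger inhibitor), three compounds sharing one core have been measured, and they differ only in the group on an amide-type nitrogen. Compound 1 `O=C(NCCCCC(c1ccc(F)cc1)c1ccc(F)cc1)Nc1ccc(Cl)cc1`, with 4-chlorophenyl there, gives 7680 nM. Compound 2 `Cc1cccc(NC(=O)NCCCCC(c2ccc(F)cc2)c2ccc(F)cc2)c1`, with 3-methylphenyl, reads > 20000 nM, which is a limit of the assay and not a number. Compound 3 `O=C(NCCCCC(c1ccc(F)cc1)c1ccc(F)cc1)Nc1ccc([N+](=O)[O-])c(Cl)c1`, with 3-chloro-4-nitrophenyl, gives 3470 nM, the lower of the two actual numbers and the strongest result so far.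

Compound 4 `Cc1ccc(NC(=O)NCCCCC(c2ccc(F)cc2)c2ccc(F)cc2)cc1C` has 3,4-dimethylphenyl in place of 3-chloro-4-nitrophenyl on an amide-type nitrogen.

For the measured compounds named here, three measured steps bear on this change. Putting 3-methylphenyl in place of 4-chlorophenyl gave an at least 2.6-fold higher number from compound 1 to compound 2 (0.41 log units; beyond the scatter). Putting 3-chloro-4-nitrophenyl in place of 4-chlorophenyl gave a 2.2-fold lower number from compound 1 to compound 3 (0.35 log units; beyond the scatter). The closest parallel is an at least 5.7-fold lower number from compound 2 to compound 3 (0.76 log units; beyond the scatter), since the new group of compound 4 also carries methyl, and the change runs the opposite way. A clearly higher number is therefore expected in this assay, undoing much of that last step. Compound 4 may also stop at the limit of > 20000 nM in this assay, at which 1 of the 3 values shown sits, so a limit rather than a number is a real possibility. The expected change is a 3.7-fold higher number from compound 3 to compound 4 (0.57 log units; beyond the scatter). The estimate for compound 4 is 13000 nM, with an expected range from 5500 nM to 25000 nM.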

Compound 4, half-maximal inhibitory concentration: > 20000 nM
Compound 4 gave a limit, no number; the forecaster's own chance of this, stated with the estimate: 40%; middle value at least 1.5-fold (0.18 log units) from the limit.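

In this assay, adding a second methyl to the ring does not bring back a measurable result: compound 2 and compound 4 both end at a limit of the assay, so the step between them cannot be read. Replacing 3-chloro-4-nitrophenyl with 3,4-dimethylphenyl gives an at least 5.7-fold higher number from compound 3 to compound 4 (0.76 log units; beyond the scatter), and replacing 4-chlorophenyl with the same group gives an at least 2.6-fold higher number from compound 1 to compound 4 (0.41 log units; beyond the scatter), so 3,4-dimethylphenyl falls short of both groups that gave actual numbers. Among these four compounds, the two with only methyl on the ring stop at the limit, while the two with chlorine on the ring, compound 1 and compound 3, give actual numbers, and no compound shown goes against this split: the limit of > 20000 nM in this assay, at which 2 of the 4 values shown sit.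

From the compounds shown here alone, how far compound 2 and compound 4 lie beyond the limit remains unknown, so the two methyl-bearing groups cannot be ranked against each other. Going by these compounds, it also remains open whether the chlorine or the nitro group matters more in compound 3, and how a phenyl ring carrying an amine or a carboxylic acid would read at this nitrogen.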